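The source may report more compounds than this note shows. Statements on the series, on what has been measured and on what is new or still open speak of the compounds shown alone.

Values in an ADME assay on J774.1 cells (Mus musculus) for cytotoxicity, read by resazurin assay, with a stated time of 48 h; on this read-out higher numbers stand for weaker inhibition and lower numbers for stronger inhibition:

- compound 1 `CCCn1cc(C(=O)NCc2ccc(OC)cc2)c(=O)c2cc(F)c(N3CCC(C(N)=O)CC3)cc21`: 41400 nM
- compound 2 `CCCCn1cc(C(=O)NCc2ccccc2)c(=O)c2cc(F)c(N(C)C)cc21`: > 100000 nM (a limit of the assay)
- compound 3 `CCCCn1cc(C(=O)NCc2ccc(OC)cc2)c(=O)c2cc(F)c(N3CCC(C(N)=O)CC3)cc21`: 40800 nM

In this assay, within the data shown here, compound 1 gives 41400 nM, level with the only other exact number available: the step is a 1.0-fold lower number from compound 1 to compound 3 (0.01 log units; within the scatter). Compound 2 is known only through a limit, > 100000 nM.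

The step now followed leads to compound 4 `CCCn1cc(C(=O)O)c(=O)c2cc(F)c(N3CCC(C(N)=O)CC3)cc21` and is hydroxy in place of (4-methoxybenzyl)amino on a carbonyl carbon. In words, it puts hydroxy in place of (4-methoxybenzyl)amino on a carbonyl carbon, so that (4-methoxybenzyl)carbamoyl becomes carboxy.

Among the measured compounds shown here, the one measured step, a 1.0-fold lower number from compound 1 to compound 3 (0.01 log units; within the scatter), concerns a saturated chain carbon and not this carbonyl carbon, so it gives no size for the present change. For the measured compounds named here, no measured compound carries the carboxy group. The expectation is therefore a judgement: a moderate move towards a higher number, meaning weaker inhibition, with the nearest reference point being (the limit of > 100000 nM in this assay, at which 1 of the 3 values shown sits). The expected step is a 2.1-fold higher number from compound 1 to compound 4 (0.31 log units; beyond the scatter). For compound 4 the estimated value is 85000 nM, with an expected range from 35000 nM to 150000 nM.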

Compound 4, half-maximal inhibitory concentration: > 100000 nM
Compound 4 gave a limit, no number; the forecaster's own chance of this, stated with the estimate: 55%; middle value at least 1.1-fold (0.07 log units) from the limit.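

In this assay, the change from (4-methoxybenzyl)carbamoyl to carboxy gives an at least 2.4-fold higher number from compound 1 to compound 4 (0.38 log units; beyond the scatter). Compound 4 gives > 100000 nM, which is a limit and not a number, so the full size of this step stays unread: the limit of > 100000 nM in this assay, at which 2 of the 4 values shown sit.

The earlier step on the saturated chain carbon, a 1.0-fold lower number from compound 1 to compound 3 (0.01 log units; within the scatter), lay within the scatter, which leaves this carbonyl carbon as the only place among the single changes shown where the read-out moves beyond the scatter.

The compounds shown leave open whether the step follows from the loss of the (4-methoxybenzyl)amino group as a whole or from the hydroxy that enters, and a methyl ester or a primary amide on this carbonyl carbon, with the rest of compound 1 kept, would separate these two readings. Also open, on these data alone, is whether a carboxy compound with a butyl chain in place of the propyl chain would stay at the limit, or whether a smaller amide, such as a benzylamide without the methoxy, would hold the value of compound 1.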